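The compounds below may be only part of what the source reports. "The series", "measured", "known", "first", "only" and "open" are said of these compounds alone.

Two related compounds have so far been tested in a functional assay on A-375 cells (Homo sapiens) for cytotoxicity, read by MTT assay, with a stated time of 72 h, tested at 30 uM; a higher number here means more inhibition of growth at the concentration tested, a lower number less inhibition of growth. In this assay compound 1 `N/C(=N\NC(=S)N1CCOCC1)c1ccc(F)cn1` gives 85.9%, while compound 2 `N/C(=N\NC(=S)N1CCN(c2ccccn2)CC1)c1ccc(F)cn1` gives 73.2%, the lower of the two numbers, with compound 1 standing above it by more than the usual scatter. Compound 3 `N/C(=N\NC(=S)N1CCN(c2ccccn2)CC1)c1ccccn1` has not yet been measured. It differs from compound 2 in one place: hydrogen in place of fluoro on an aromatic carbon. Going by the values given here, no measured pair here shows what this change does. In this assay the step of a number 3.2 percentage points lower from compound 2 to compound 3 (within the scatter) is expected to be small, of uncertain direction and probably within the scatter. Compound 3 is therefore estimated at 70%, in a range from 50% to 88%.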

Compound 3, percent growth inhibition at one concentration: 81%
Compound 3: the middle estimate sits 11 percentage points below what was measured; measured number inside the range.
By their numbers in this assay, from the lowest: compounds 2, 3 and 1 (each within the scatter of the next, the first and the last beyond it).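

In this assay the change from 5-fluoropyridin-2-yl to pyridin-2-yl brings a number 7.8 percentage points higher from compound 2 to compound 3 (within the scatter) for this pair. Going by these compounds alone, this is the first direct reading of the change, and it shows that on this core growth inhibition at the concentration tested does not depend measurably on the fluoro, which hydrogen can replace without a step beyond the scatter. No measurement offered here bears on why the fluoro matters so little.

Still open, as far as these compounds go, is whether a larger group at this place, such as methoxy or an amine, would keep the effect. From the compounds shown here alone, the same change on compound 1 also remains open.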